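Ethyl to propyl on the shared core: expected effect

The source may hold more compounds than are shown below. What is called first, only, known or untested is meant among the compounds shown, and "the series" means these compounds.

Two compounds of this series have numbers in a functional assay on the whole organism (strain Swiss Albino) for inhibition, with Mus musculus as the target, read by paw edema, with a stated time of 360 min, at a dose of 100 mg/kg by the oral route; on this read-out lower numbers stand for less inhibition and higher numbers for more inhibition at the one dose given (going by the name of the read-out). Compound 1 `CCCNC(=S)N1N=C(c2ccc(C)cc2)CC1c1ccc[nH]1` gives 22.7% in this assay. Compound 2 `CCNC(=S)N1N=C(c2ccc(OC)cc2)CC1c1ccc[nH]1` gives 27.6% in this assay, the highest of the two numbers, but its gap to compound 1 lies within the scatter, so the two readings cannot be told apart. Going by the values given here, no single-point step between measured compounds exists; compound 1 and compound 2 differ in two places at once, and their values alone show no separation.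

Compound 3 `CCCNC(=S)N1N=C(c2ccc(OC)cc2)CC1c1ccc[nH]1` is not yet measured. It differs from compound 2 by methyl in place of hydrogen on a saturated chain carbon, two bonds along the chain from an amide-type nitrogen. Nothing measured in this series speaks to that change. With compound 1 and compound 2 indistinguishable in this assay, no step beyond the scatter is expected for the move to compound 3 in either direction. Compound 3 is estimated at 27% in this assay, with a range from 15% to 38%; the expected step is a number 0.6 percentage points lower from compound 2 to compound 3 (within the scatter).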

Compound 3, a percentage reported as inhibition, in the whole organism at one dose (the size of the read-out at that dose, not a potency): 32.8%
Compound 3: middle estimate off by 5.8 percentage points, on the low side; the range from low to high includes it.
By their numbers in this assay, from the lowest: compounds 1, 2 and 3 (each within the scatter of the next, the first and the last beyond it).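

In this assay the change on the saturated chain carbon, two bonds along the chain from an amide-type nitrogen, gives a number 5.2 percentage points higher from compound 2 to compound 3 (within the scatter) and so does not separate ethylamino from propylamino at this position. Compound 3 also provides the first comparison in one place on the aromatic carbon, where methoxy in place of methyl gives a number 10.1 percentage points higher from compound 1 to compound 3 (beyond the scatter) as a modest step, the only step shown that clears the scatter. No measurement at hand offers a cause for either step.

From the compounds shown here alone, whether a butyl chain or a longer chain at the chain position would give a step beyond the scatter remains open. Also open, going by these compounds, is how chloro or an amine on the aromatic carbon would compare with methoxy on the same propylamino compound.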